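Replacing diethylamino with 4-methylpiperidin-1-yl in compound 3

The compounds below may be only part of what the source reports. "The series", "measured", "known", "first", "only" and "open" are said of these compounds alone.

In a functional assay on NCI-H460 cells (Homo sapiens) for cytotoxicity, read by MTT assay, with a stated time of 72 h (a lower number here means a stronger inhibitor, a higher number a weaker inhibitor), compound 3 `CCN(CC)Cc1ccc2nc(NC(=O)N/N=C/c3cn(Cc4ccccc4)c4ccccc34)sc2c1` gives 450 nM as its value and sits within the scatter of compound 2 `CN(C)Cc1ccc2nc(NC(=O)N/N=C/c3cn(Cc4ccccc4)c4ccccc34)sc2c1` at 400 nM. Compound 1 `CC1CCN(Cc2ccc3nc(NC(=O)N/N=C/c4c[nH]c5ccccc45)sc3c2)CC1` reads a clearly higher 4130 nM as its value. Compound 4 `CC1CCN(Cc2ccc3nc(NC(=O)N/N=C/c4cn(Cc5ccccc5)c5ccccc45)sc3c2)CC1` has 4-methylpiperidin-1-yl in place of diethylamino on a saturated chain carbon bound to an aromatic carbon. Within the data shown here, one measured step bears on this change, a swap at the same carbon, and it is small (a 1.1-fold higher number from compound 2 to compound 3 (0.05 log units; within the scatter)). No step beyond the scatter is therefore expected in this assay (a 1.1-fold higher number from compound 3 to compound 4 (0.05 log units; within the scatter)). Compound 4 is estimated at 500 nM, with an expected range from 190 nM to 1400 nM.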

Compound 4, half-maximal inhibitory concentration: 1910 nM
The estimate for compound 4 lay 3.8-fold (0.58 log units) below the measured number, and the stated range ends below it.
By their numbers in this assay, from the lowest: compounds 2 and 3 (each within the scatter of the next); then compound 4; then compound 1.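

At this saturated chain carbon, the identity of the amine matters in this assay: 4-methylpiperidin-1-yl in place of diethylamino gives a clear step (a 4.2-fold higher number from compound 3 to compound 4 (0.63 log units; beyond the scatter)), as does 4-methylpiperidin-1-yl in place of dimethylamino (a 4.8-fold higher number from compound 2 to compound 4 (0.68 log units; beyond the scatter)). With 4-methylpiperidin-1-yl held constant, benzyl in place of hydrogen on the aromatic nitrogen also gives a step beyond the scatter (a 2.2-fold lower number from compound 1 to compound 4 (0.33 log units; beyond the scatter)). On these data alone, whether the ring or its methyl group carries the amine step remains open, as does how piperidin-1-yl or morpholin-4-yl would read. The compounds also leave open how benzyl in place of hydrogen reads with diethylamino. Nothing available here explains these steps.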